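A few compounds are considered here, and "the series" means these few. Any claim that something is new, unique, unknown or untested is made for them only; others in the source may bear on it.

Compound 2 `Oc1ccccc1CNc1ccc(-c2ccc(Cl)cc2)cc1` is tested in a functional assay on Jurkat cells (Homo sapiens) for activation, with a stated time of 24 h (a lower number here means that less compound is needed, a higher number that more compound is needed for the effect), and gives 2390 nM. Of the two compounds with a number, compound 2 has the lowest; its nearest neighbour is compound 3 `Oc1ccccc1CNc1ccc(-c2cccc(Cl)c2)cc1`, which gives 6200 nM, the step being a 2.6-fold higher number from compound 2 to compound 3 (0.41 log units; beyond the scatter). Compound 1 `O=[N+]([O-])c1ccc(NCc2ccccc2O)cc1` is reported in this assay as "not active" (no number reported), without a number.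

Compound 4 `CCSc1ccc(-c2ccc(NCc3ccccc3O)cc2)cc1` has not yet been measured. It differs from compound 2 in one place: ethylsulfanyl in place of chloro on an aromatic carbon. Going by the values given here, the only measured step, from compound 2 to compound 3, puts 3-chlorophenyl in place of 4-chlorophenyl on an aromatic carbon; it keeps chloro and exchanges it for nothing, so no measured step bears directly on replacing chloro with ethylsulfanyl. With nothing to lean on, the expected step in this assay for compound 4 is none beyond the scatter, with a wide range on both sides. Compound 4 is therefore expected to give 3000 nM in this assay, between 800 nM and 12000 nM. The expected step is a 1.3-fold higher number from compound 2 to compound 4 (0.10 log units; within the scatter).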

Compound 4, half-maximal effective concentration: 1980 nM
For compound 4 the middle estimate is 1.5-fold (0.18 log units) above the measured one, within the range that was stated.
By their numbers in this assay, from the lowest: compounds 4 and 2 (each within the scatter of the next); then compound 3.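

In this assay, ethylsulfanyl in place of chloro gives a 1.2-fold lower number from compound 2 to compound 4 (0.08 log units; within the scatter), so at this place, para to a large group, the read-out does not tell the two groups apart. The earlier step, a 2.6-fold higher number from compound 2 to compound 3 (0.41 log units; beyond the scatter), kept the chlorine and only put 3-chlorophenyl in place of 4-chlorophenyl, whereas this change shows that a different group with 3 heavy atoms, including a sulfur, can stand where chloro with its 1 heavy atom stood and the number stays within the scatter. No measurement shown here explains why the two groups give matching numbers.

On these data alone, it remains open how much larger this group can become, for example a longer chain such as hexylsulfanyl. As far as these compounds go, whether an amine or a carboxylic acid at the same place would give a comparable number also remains open.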